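Series notes: heteroaryl exchange on the shared core

The source may report more compounds than this note shows. Statements on the series, on what has been measured and on what is new or still open speak of the compounds shown alone.

Compound 1 `Oc1ccc(-c2cc(-c3ccc(Cl)cc3)nc(-c3cccs3)c2)cc1` is the reference point. Among the compounds with values here, in a functional assay on T47D cells (Homo sapiens) for cytotoxicity, read by CCK-8 assay and cell counting, with a stated time of 2 days (a lower number here means a stronger inhibitor, a higher number a weaker inhibitor), compound 1 gives 6450 nM, the highest of the two numbers measured so far. Its nearest neighbour, compound 2 `Oc1ccc(-c2cc(-c3cccc(Cl)c3)nc(-c3cccs3)c2)cc1`, carries 3-chlorophenyl in place of 4-chlorophenyl on an aromatic carbon; in this assay compound 2 gives 5350 nM, and the step of a 1.2-fold lower number from compound 1 to compound 2 (0.08 log units; within the scatter) stays within the scatter, so the two numbers stand together rather than apart.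

Compound 3 `Oc1ccc(-c2cc(-c3ccc(Cl)cc3)nc(-c3ccccn3)c2)cc1` keeps the 4-chlorophenyl group and the 4-hydroxyphenyl group of compound 1 and differs only in the heteroaryl: pyridin-2-yl in place of thiophen-2-yl on an aromatic carbon. Within the data shown here, the single measured step, from compound 1 to compound 2, concerns the chlorophenyl group and not the heteroaryl, so no measured step bears on this change; the series holds no example of exchanging a five-membered aromatic ring for a six-membered aromatic ring at this place. The expectation is therefore no step beyond the scatter, with the range widened for the lack of precedent. The step from compound 1 to compound 3 is expected to be a 1.0-fold higher number from compound 1 to compound 3 (0.00 log units; within the scatter). Compound 3 is accordingly estimated at 6500 nM in this assay, within 2500 nM to 17000 nM.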

Compound 3, half-maximal inhibitory concentration: 25900 nM
For compound 3 the middle estimate is 4.0-fold (0.60 log units) below the measured one, outside the stated range (above it).
By their numbers in this assay, from the lowest: compounds 2 and 1 (each within the scatter of the next); then compound 3.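

In this assay the heteroaryl place responds where the chlorophenyl exchange did not: pyridin-2-yl in place of thiophen-2-yl gives a 4.0-fold higher number from compound 1 to compound 3 (0.60 log units; beyond the scatter), while moving the chlorine gave a 1.2-fold lower number from compound 1 to compound 2 (0.08 log units; within the scatter). Within the data shown here, this place, on an aromatic carbon next to the ring nitrogen, is therefore not indifferent to the group it carries, although the single step changes ring size and hetero atom together and cannot separate the two. Nothing on hand accounts for the step.

Open, going by these compounds, is whether furan-2-yl, with oxygen in a five-membered aromatic ring, or an unsubstituted phenyl at this place would stand with thiophen-2-yl or with pyridin-2-yl, and whether pyridin-3-yl would read as pyridin-2-yl does. Also open, on these data alone, is whether the same heteroaryl exchange would give a similar step on the 3-chlorophenyl group of compound 2, and whether an amine or a carboxylic acid in place of the hydroxyl of the 4-hydroxyphenyl group would shift the numbers at all.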